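Dropping the chloromethyl from compound 1: expected aromatase inhibition

The source may hold more compounds than are shown below. What is called first, only, known or untested is meant among the compounds shown, and "the series" means these compounds.

Measured so far:
- compound 1, `NCCOc1ccc(/C(=C(\CCCl)c2ccccc2)c2ccc(O)cc2)cc1`: 143 nM
- compound 2, `NCCOc1ccc(/C(=C2\CCc3ccccc32)c2ccc(O)cc2)cc1`: 493 nM
- compound 3, `NCCOc1ccc(C(=C(c2ccccc2)c2ccccc2)c2ccc(O)cc2)cc1`: 1930 nM

All three were tested in an assay on isolated protein for inhibition of Aromatase (Homo sapiens), read by fluorescence, with a stated time of 30 min; on this read-out higher numbers stand for weaker inhibition and lower numbers for stronger inhibition. Compound 1 has the lowest number of the three; compound 2 stands higher by a gap beyond the scatter, and compound 3 higher still.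

The next compound, compound 4 `C/C(=C(/c1ccc(O)cc1)c1ccc(OCCN)cc1)c1ccccc1`, differs from compound 1 in one place: hydrogen in place of chloromethyl on a saturated chain carbon bound to a double-bonded chain carbon. Among the measured compounds shown here, no measured pair shows this exact change, but the trend from compound 1 to compound 3 hints that the weaker inhibition follows when the chain is shortened. The step from compound 1 to compound 4 is therefore expected to weaken inhibition, estimated as a 2.8-fold higher number from compound 1 to compound 4 (0.45 log units; beyond the scatter).

Compound 4 is expected to give 400 nM, in a range from 150 nM to 1200 nM.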

Compound 4, half-maximal inhibitory concentration: 337 nM
The estimate for compound 4 lay 1.2-fold (0.07 log units) above the measured number; the measured number falls inside the stated range.
By their numbers in this assay, from the lowest: compound 1; then compounds 4 and 2 (each within the scatter of the next); then compound 3.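

In this assay, among the compounds shown here, hydrogen in place of chloromethyl gives a 2.4-fold higher number from compound 1 to compound 4 (0.37 log units; beyond the scatter), the first direct reading of a change at this position. The 2-chloroethyl group therefore adds a modest gain over methyl, yet compound 4, without chlorine, still gives 337 nM. Nothing available explains the size of this step.

The compounds shown leave open whether the gain comes from the chlorine or from the longer chain. An ethyl group at this place, with the same chain length and no chlorine, would separate the two.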